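The source may report more compounds than this note shows. Statements on the series, on what has been measured and on what is new or still open speak of the compounds shown alone.

Compound 1 `Nc1cc(C2CCNCCc3cccc(c3)OCc3cccc(c3)Cn3cc2cn3)c2nn[nH]c2n1` — in an assay on isolated protein for inhibition of Myeloperoxidase (Homo sapiens), with a stated time of 10 min (a lower number here means a stronger inhibitor, a higher number a weaker inhibitor), compound 1 gives 17 nM.
Compound 2 `Nc1cc(Cc2ccn(Cc3cccc(Oc4cccc5c4CNC5)c3)n2)c2nn[nH]c2n1` — in this assay compound 2 gives 26 nM.
Compound 3 `Nc1cc(C2CCNCc3cccc(c3)OCc3cccc(c3)Cn3cc2cn3)c2nn[nH]c2n1` — in this assay compound 3 gives 8 nM.

Of these three numbers, compound 2 stands highest. Its nearest neighbour is compound 1, whose number lies within the usual scatter of it, so no order between the two can be claimed. Compound 3 lies further off, beyond the scatter, and so shows the stronger inhibition of that pair.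

Compound 4 `Nc1cc(Cc2ccn(Cc3cccc(O[C@H]4CCNC4)c3)n2)c2nn[nH]c2n1` has not yet been measured in this assay. It differs from compound 2 in one place: a group of 5 heavy atoms (4 carbon, 1 nitrogen; one five-membered non-aromatic ring with 1 hetero atom) in place of a group of 9 heavy atoms (8 carbon, 1 nitrogen; one five-membered non-aromatic ring with 1 hetero atom, one six-membered aromatic ring of carbon only), on an oxygen on an aromatic ring. Among the measured compounds shown here, no two measured compounds differ in a single place, so there is no measured step of this kind to lean on, and the expectation rests on the change itself and on the number of compound 2 alone. The account expects a modest weakening, in the direction of a higher number, that may or may not exceed the scatter, estimated as a 1.9-fold higher number from compound 2 to compound 4 (0.28 log units; within the scatter). For compound 4 in this assay the expected value is 50 nM, with a range from 15 nM to 200 nM.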

Compound 4, half-maximal inhibitory concentration: 46 nM
For compound 4 the middle estimate is 1.1-fold (0.04 log units) above the measured one; measured number inside the range.
By their numbers in this assay, from the lowest: compound 3; then compounds 1, 2 and 4 (each within the scatter of the next, the first and the last beyond it).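

In this assay, putting pyrrolidin-3-yl in place of the larger group, on an oxygen on an aromatic ring, gives a 1.8-fold higher number from compound 2 to compound 4 (0.25 log units; within the scatter) and lies within the scatter, so no order between the two compounds can be claimed. This single-place step shows that, at this position, a group without the six-membered aromatic ring of carbon only can stand in this assay with no change beyond the scatter. Nothing measured here accounts for the step.

As far as these compounds go, whether the opposite stereocentre of pyrrolidin-3-yl, a piperidin-4-yl ring or an open aminoethyl chain on the same oxygen would stay within the scatter of compound 4 remains open. So does the role of the ring nitrogen, which a tetrahydrofuran-3-yl group in its place would test.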